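The source may report more compounds than this note shows. Statements on the series, on what has been measured and on what is new or still open speak of the compounds shown alone.

The compounds share one core. Compound 1 `C/C(=C\c1cc(-c2ccc(C(F)(F)F)cc2)cs1)C(N)=O` carries a trifluoromethyl group on its outer aromatic ring. In a functional assay on T-24 cells (Homo sapiens) for cytotoxicity, read by CCK-8 assay, with a stated time of 24 h (on this read-out higher numbers stand for weaker inhibition and lower numbers for stronger inhibition), compound 1 gives > 50000 nM, which is a limit of the assay rather than a number. Compound 2 `C/C(=C\c1cc(-c2ccc(Cl)cc2)cs1)C(N)=O` carries chloro in place of trifluoromethyl on an aromatic carbon. In this assay compound 2 gives > 50000 nM, likewise a limit of the assay. The step that the two limits leave unreadable from compound 1 to compound 2 cannot be read in size or direction because of the limit of > 50000 nM in this assay, at which 2 of the 2 values shown sit. Among the measured compounds shown here, compound 2 thus stands at the limit, the same place where the only other value shown also sits.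

Compound 3 `COc1ccc(-c2csc(/C=C(\C)C(N)=O)c2)cc1` differs from compound 2 in one place: methoxy in place of chloro on an aromatic carbon. For the measured compounds named here, the one measured step, a step that the two limits leave unreadable from compound 1 to compound 2, concerns an exchange on the same aromatic carbon yet has no readable size, so it supplies no direction for this change. Compound 3 is therefore expected to show a step of a number no higher from compound 2 to compound 3 (the limit leaves the size open) that is most likely not readable either. Compound 3 is expected to give about 50000 nM, somewhere between 10000 nM and 200000 nM, with a limit rather than a number the likelier outcome.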

Compound 3, half-maximal inhibitory concentration: > 50000 nM
Compound 3 ended at the assay's limit; the forecaster's own chance of this, stated with the estimate: 75%; the middle value sits exactly at the limit.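

Compound 3, like compound 1 and compound 2, gives only a limit of the assay in this assay, so no new step can be read among these three compounds: (the limit of > 50000 nM in this assay, at which 3 of the 3 values shown sit). The compounds shown leave open whether trifluoromethyl, chloro and methoxy on this aromatic carbon differ at all in this assay, and how far each compound lies from the limit.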